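A few compounds are considered here, and "the series" means these few. Any claim that something is new, unique, unknown or untested is made for them only; others in the source may bear on it.

Three compounds have so far been measured in a functional assay on Caco-2 cells (Homo sapiens) for cytotoxicity, with a stated time of 48 h; on this read-out lower numbers stand for stronger inhibition and higher numbers for weaker inhibition:

compound 1 `O=[N+]([O-])c1ccc(CN2CCC(n3cc(CC(OCc4cc(-c5ccc(Br)cc5)no4)c4ccc(Br)cc4)nn3)CC2)cc1`, 3000 nM
compound 2 `O=[N+]([O-])c1ccc(CN2CCC(n3cc(CC(OCc4cc(-c5ccc(F)cc5)no4)c4ccc(Br)cc4)nn3)CC2)cc1`, 3000 nM
compound 3 `O=[N+]([O-])c1ccc(CN2CCC(n3cc(CC(OCc4cc(-c5ccccc5Br)no4)c4ccc(Br)cc4)nn3)CC2)cc1`, 3000 nM

Compound 1 and compound 2 differ by one change, (fluoro in place of bromo on an aromatic carbon), and the step of no change at the digits printed from compound 1 to compound 2 (within the scatter). Compound 3 carries the same atoms as compound 1 joined differently, (2-bromophenyl in place of 4-bromophenyl on an aromatic carbon), and the step of no change at the digits printed from compound 1 to compound 3 (within the scatter); likewise the step of no change at the digits printed from compound 2 to compound 3 (within the scatter). All three values therefore sit together, and none can be called stronger or weaker than another.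

Compound 4 `O=[N+]([O-])c1ccc(CN2CCC(n3cc(CC(OCc4cc(-c5ccccc5F)no4)c4ccc(Br)cc4)nn3)CC2)cc1` has not yet been measured in this assay. It differs from compound 3 by fluoro in place of bromo on an aromatic carbon. Among the compounds with values here, this is the same kind of change as the one from compound 1 to compound 2, but not the same change: in the earlier pair the place was para to a large group, whereas here it is ortho to a large group. Because the earlier step of no change at the digits printed from compound 1 to compound 2 (within the scatter) stayed within the scatter, and the core change no change at the digits printed from compound 1 to compound 3 (within the scatter) did as well, the step to compound 4 is expected to be no change at the digits printed from compound 3 to compound 4 (within the scatter). Compound 4 is thus estimated to give about 3000 nM in this assay, with a plausible range from 1500 nM to 6000 nM.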

Compound 4, half-maximal inhibitory concentration: 4000 nM
Estimate against measurement, compound 4: 1.3-fold (0.12 log units) below; the measured number falls inside the stated range.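

In this assay, the exchange of bromo for fluoro looks the same on the two cores: the same change on two cores in this assay, no change at the digits printed (within the scatter) from compound 1 to compound 2 and a 1.3-fold higher number (0.12 log units; within the scatter) from compound 3 to compound 4, 1.3-fold (0.12 log units) apart, within the scatter of two such steps

The new step is a 1.3-fold higher number from compound 3 to compound 4 (0.12 log units; within the scatter), and the other two steps that reach compound 4 read the same way, a 1.3-fold higher number from compound 2 to compound 4 (0.12 log units; within the scatter) and a 1.3-fold higher number from compound 1 to compound 4 (0.12 log units; within the scatter). Within the data shown here, this shows that, for these two cores, the exchange carries over without a difference that can be told from the scatter, but it rests on only two pairs in a single assay whose values all sit together, so it does not show that the exchange would behave this way on another core or in another assay.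

The compounds shown leave open whether anything other than a halogen on the phenyl ring, such as an amine, a carboxylic acid or a methoxy group, would shift the number beyond the scatter. They also leave open what the values would do with a group such as a nitrile in place of the nitro group.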